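From Chlorophenyl to Trifluoromethylphenyl on a Sulfonyl Sulfur

This account rests on a few compounds, and the source may have more. Where it says the series, first, only, none or still open, it means among the compounds named here.

Compound 1 `N=C(NS(=O)(=O)c1cccc(Cl)c1)N1CCN(c2cc3c(cc2F)c(=O)c(C(=O)O)cn3C2CC2)CC1` and compound 2 `N=C(NS(=O)(=O)c1ccc(Cl)cc1)N1CCN(c2cc3c(cc2F)c(=O)c(C(=O)O)cn3C2CC2)CC1` share one core and differ only in the chlorophenyl group on a sulfonyl sulfur. For the measured compounds named here, in a functional assay on HL-60 cells (Homo sapiens) for antiproliferative activity, read by MTT assay, with a stated time of 72 h (on this read-out lower numbers stand for stronger inhibition and higher numbers for weaker inhibition), compound 1 gives 43 nM and compound 2 gives 43 nM, so compound 2 stands level with its only measured neighbour.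

The next molecule, compound 3 `N=C(NS(=O)(=O)c1ccccc1C(F)(F)F)N1CCN(c2cc3c(cc2F)c(=O)c(C(=O)O)cn3C2CC2)CC1`, changes that same group: 2-(trifluoromethyl)phenyl in place of 4-chlorophenyl on a sulfonyl sulfur. Here a 2-(trifluoromethyl)phenyl replaces the 4-chlorophenyl, so both the substituent and its place on the ring differ.

Going by the values given here, only one measured step bears on this change, and it shows no change at the digits printed from compound 1 to compound 2 (within the scatter). That step replaced 3-chlorophenyl with 4-chlorophenyl, so this small series has so far shown no sensitivity to where the chlorine sits. However, no measured compound carries a 2-(trifluoromethyl)phenyl, which leaves the new group untested and calls for a wide range.

The expected result in this assay is therefore little change, with a slight lean toward weaker inhibition. The estimated step is a 1.4-fold higher number from compound 2 to compound 3 (0.14 log units; within the scatter). The estimate for compound 3 is 60 nM, with an expected range of 20 nM to 180 nM.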

Compound 3, half-maximal inhibitory concentration: 43 nM
Beside the measured number, compound 3's estimate is 1.4-fold (0.14 log units) above it; the measured number falls inside the stated range.
By their numbers in this assay, from the lowest: compounds 1, 2 and 3 (each within the scatter of the next).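

In this assay the new group gives no change at the digits printed from compound 2 to compound 3 (within the scatter) and, set against the other chlorophenyl, no change at the digits printed from compound 1 to compound 3 (within the scatter) on the same read-out. The earlier pair moved only a chlorine around the ring, whereas this change replaces the substituent as well as its place, with 10 heavy atoms entering where 7 leave, so the level result on the sulfonyl sulfur now covers a trifluoromethyl group as well as chlorine. No supporting data are available to explain why these three groups read alike.

All three compounds still carry a phenyl ring with a chlorine or a trifluoromethyl group on the sulfonyl sulfur, so the series does not yet show what, if anything, at this position would move the number. An amine or a methoxy group on that ring, or a longer alkyl chain in place of the ring itself, would test whether this level result extends to substituents of a different kind or holds only for the groups seen so far.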